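Pyridin-3-yl in place of methyl on the shared core

The compounds below may be only part of what the source reports. "The series", "measured", "known", "first", "only" and "open" are said of these compounds alone.

Within the data shown here, compound 2 `Cc1nc2c3ccccc3ccc2c2nc3c(ccc4ccccc43)c(C)c12` has the highest of the two numbers measured so far in a functional assay, read by spectrophotometry, with a stated time of 15 min; on this read-out higher numbers stand for weaker inhibition and lower numbers for stronger inhibition; in this assay compound 2 gives 89.6 ug/mL. Its nearest neighbour is compound 1 `Cc1nc2c3ccccc3ccc2c2nc3c(ccc4ccccc43)c(-c3cccc([N+](=O)[O-])c3)c12`, which in this assay gives 54.2 ug/mL, a step of a 1.7-fold higher number from compound 1 to compound 2 (0.22 log units; within the scatter), so the two stand within the scatter of each other and no order between them can be claimed.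

Compound 3 `Cc1nc2c3ccccc3ccc2c2nc3c(ccc4ccccc43)c(-c3cccnc3)c12` differs from compound 2 by pyridin-3-yl in place of methyl on an aromatic carbon. Among the measured compounds shown here, the only measured step that bears on this change is the one from compound 1 to compound 2, which swapped an aromatic six-membered ring for a methyl at the same place and moved the number by a 1.7-fold higher number from compound 1 to compound 2 (0.22 log units; within the scatter), within the scatter. Putting an aromatic six-membered ring back in place of the methyl is therefore expected to give a small step in the other direction, most likely no larger than the scatter, so compound 3 is expected to land near compound 1 and compound 2 rather than clearly apart from them.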

Compound 3, half-maximal inhibitory concentration: 63.6 ug/mL
Compound 3: middle estimate off by 1.1-fold (0.03 log units), on the low side; measured number inside the range.
By their numbers in this assay, from the lowest: compounds 1, 3 and 2 (each within the scatter of the next).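

In this assay, pyridin-3-yl in place of methyl on this aromatic carbon gives a 1.4-fold lower number from compound 2 to compound 3 (0.15 log units; within the scatter) while pyridin-3-yl in place of 3-nitrophenyl gives a 1.2-fold higher number from compound 1 to compound 3 (0.07 log units; within the scatter) and so neither step can be read as a real change. Among these compounds, this carbon, opposite the ring nitrogen, has now carried a methyl and two different six-membered aromatic rings, one of them with a ring nitrogen and a hydrogen-bond acceptor, and no step among compound 1, compound 2 and compound 3 lies beyond the scatter. Nothing at hand speaks to the reason for this closeness.

The compounds shown leave open whether any group on this carbon can move the number beyond the scatter, as all three carry either a methyl or a six-membered aromatic ring there. How an amine, a carboxylic acid or a longer chain at this place would stand against compound 1, compound 2 and compound 3 remains an open question, as does the effect of moving the ring nitrogen of the pyridine to another position.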